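Hydroxycyclohexyl for methyl on a urea nitrogen

The source may hold more compounds than are shown below. What is called first, only, known or untested is meant among the compounds shown, and "the series" means these compounds.

compound 1, `CN(C(=O)NCCCOc1ccc2nc(O)ccc2c1)C1CCCCC1`: 21%
compound 2, `O=C(NCCCOc1ccc2nc(O)ccc2c1)N(C1CC1)[C@@H]1CCCCC[C@H]1O`: 44%
compound 3, `CN(C(=O)NCCCOc1ccc2nc(O)ccc2c1)[C@@H]1CCCC[C@H]1O`: 18%

In a functional assay on the whole organism for inhibition, with Mus musculus as the target, at a dose of 30 mg/kg by the oral route (a higher number here means more inhibition at the dose given (going by the name of the read-out), a lower number less inhibition), compound 1 gives 21%, the second highest of the three numbers; compound 3 lies nearest, within the scatter, and compound 2 gives the highest value, beyond the scatter from compound 1. Compound 4 `O=C(NCCCOc1ccc2nc(O)ccc2c1)N(C1CCCCC1)[C@H]1CCCC[C@@H]1O` differs from compound 1 by 2-hydroxycyclohexyl in place of methyl on an amide-type nitrogen. Among the measured compounds shown here, one measured step bears on this change: a number 3 percentage points lower from compound 1 to compound 3 (within the scatter), so the hydroxy alone moves nothing beyond the scatter. For the measured compounds named here, no measured step exchanges the methyl for a ring on that nitrogen; compound 2, with rings on that nitrogen, gives 44%. A modest rise is therefore expected, a number 9 percentage points higher from compound 1 to compound 4 (within the scatter), and compound 4 is estimated at 30%, ranging from 10% to 52%.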

Compound 4, a percentage reported as inhibition, in the whole organism at one dose (the size of the read-out at that dose, not a potency): 57%
The estimate for compound 4 lay 27 percentage points below the measured number; the measured number lies above the stated range.
By their numbers in this assay, from the lowest: compounds 3 and 1 (each within the scatter of the next); then compound 2; then compound 4.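

In this assay, the amide-type nitrogen proves to be a place where the number can move far: 2-hydroxycyclohexyl in place of methyl gives a number 36 percentage points higher from compound 1 to compound 4 (beyond the scatter). The only earlier step, a number 3 percentage points lower from compound 1 to compound 3 (within the scatter), stayed within the scatter, so this is the first single change shown to go beyond it. Nothing available explains the rise. The compounds shown leave open whether the ring or its hydroxy carries the rise. A plain cyclohexyl on that nitrogen, or an amine in place of the hydroxy, would help separate the two.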